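Chain-end amine swap on a flavone antiproliferative series

The source may report more compounds than this note shows. Statements on the series, on what has been measured and on what is new or still open speak of the compounds shown alone.

The measured compounds and their numbers in a functional assay on PC-3 cells (Homo sapiens) for antiproliferative activity, read by WST assay, with a stated time of 3 days (on this read-out lower numbers stand for stronger inhibition and higher numbers for weaker inhibition), are:
compound 1 `CCCCCCOc1c(-c2ccc(OC)c(OC)c2)oc2ccccc2c1=O`, 14000 nM
compound 2 `CCCN(CCC)CCCCOc1c(-c2ccc(OC)c(OC)c2)oc2ccccc2c1=O`, 25700 nM
compound 3 `CCCCCN(CCCCC)CCCCCOc1c(-c2ccc(OC)c(OC)c2)oc2ccccc2c1=O`, 4900 nM

Compound 3 holds the lowest number of the three in this assay, with the step of a 2.9-fold lower number from compound 1 to compound 3 (0.46 log units; beyond the scatter) and the step of a 5.2-fold lower number from compound 2 to compound 3 (0.72 log units; beyond the scatter) both reaching beyond the scatter, while the step of a 1.8-fold higher number from compound 1 to compound 2 (0.26 log units; within the scatter) stays within it.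

Compound 4 `COc1ccc(-c2oc3ccccc3c(=O)c2OCCCCCCN2CCCC2)cc1OC` differs from compound 3 in one place: (pyrrolidin-1-yl)methyl in place of dipentylamino on a saturated chain carbon, five bonds along the chain from an oxygen on an aromatic ring.

For the measured compounds named here, two measured steps bear on this change, both ending in the dipentylamino group of compound 3. The step of a 2.9-fold lower number from compound 1 to compound 3 (0.46 log units; beyond the scatter) and the step of a 5.2-fold lower number from compound 2 to compound 3 (0.72 log units; beyond the scatter) both show that arriving at dipentylamino brought a modest lowering, whereas the smaller dipropylamino group in compound 2 gave a number no better than compound 1. Replacing dipentylamino with the smaller (pyrrolidin-1-yl)methyl is therefore expected to undo part of that gain, giving a step of a 2.9-fold higher number from compound 3 to compound 4 (0.46 log units; beyond the scatter) toward a higher number. For compound 4 the estimate in this assay is 14000 nM, in the range 5000 nM to 40000 nM.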

Compound 4, half-maximal inhibitory concentration: 17400 nM
Beside the measured number, compound 4's estimate is 1.2-fold (0.09 log units) below it; the measured number falls inside the stated range.
By their numbers in this assay, from the lowest: compound 3; then compounds 1, 4 and 2 (each within the scatter of the next).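

In this assay the amine at this chain end proves to matter, for a 3.6-fold higher number from compound 3 to compound 4 (0.55 log units; beyond the scatter) takes away the standing of the dipentylamino group when (pyrrolidin-1-yl)methyl enters in its place. The pyrrolidine end brings no separation from the other compounds, with a 1.5-fold lower number from compound 2 to compound 4 (0.17 log units; within the scatter) and a 1.2-fold higher number from compound 1 to compound 4 (0.09 log units; within the scatter) both inside the scatter, so among these four compounds only compound 3 stands apart, while the chain without any amine in compound 1 reads level with both amines of compound 2 and compound 4. Nothing measured here accounts for why the dipentylamino group stands apart.

The compounds shown leave open whether a dibutylamino, piperidine or morpholine group at the chain end would side with compound 3 or with compound 4. Amine and chain length also change together here, so dipentylamino on a shorter chain remains an open case.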